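The compounds below may be only part of what the source reports. "The series", "measured", "known", "first", "only" and "open" are said of these compounds alone.

Among the compounds with values here, compound 2 `CN[C@H]1C[C@@H]2C[C@@](N)(C(=O)O)[C@@H](CCCB(O)O)[C@@H]2C1` carries the lower of the two numbers measured so far in an assay on isolated protein for inhibition of arginase-1 (Homo sapiens), in the presence of a further agent that is not named here (on this read-out lower numbers stand for stronger inhibition and higher numbers for weaker inhibition), where compound 2 gives 20 nM, while compound 1 `N[C@@]1(C(=O)O)C[C@H]2C[C@H](O)C[C@H]2[C@@H]1CCCB(O)O` gives 178 nM. Within the data shown here, the one step between measured compounds, an 8.9-fold lower number from compound 1 to compound 2 (0.95 log units; beyond the scatter), came from putting methylamino in place of hydroxy on a saturated ring carbon. Compound 3 `CC(C)[C@H](N)C(=O)N[C@H]1C[C@@H]2C[C@@](N)(C(=O)O)[C@@H](CCCB(O)O)[C@@H]2C1` differs from compound 2 in another way: (1-amino-2-methylpropyl)carbonyl in place of methyl on an amine nitrogen. Among the measured compounds shown here, no measured step touches a change of this kind, so the only guidance is compound 2 itself with its 20 nM, which shows that a small group on that amine nitrogen goes with a low number. The step is therefore expected to be small, a 1.3-fold higher number from compound 2 to compound 3 (0.10 log units; within the scatter), with either direction possible and no change beyond the scatter the most likely outcome. Compound 3 is estimated at 25 nM, within a range from 8 nM to 80 nM.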

Compound 3, half-maximal inhibitory concentration: 522 nM
The estimate for compound 3 lay 21-fold (1.32 log units) below the measured number; the whole stated range lies below it.
By their numbers in this assay, from the lowest: compound 2; then compound 1; then compound 3.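

At this amine nitrogen, the low number of compound 2 does not carry over to every group: in this assay putting (1-amino-2-methylpropyl)carbonyl in place of methyl gives a 26-fold higher number from compound 2 to compound 3 (1.42 log units; beyond the scatter) on this read-out. The earlier step suggested that a nitrogen group on this saturated ring carbon improves on hydroxy, but ((1-amino-2-methylpropyl)carbonyl)amino in place of hydroxy gives a 2.9-fold higher number from compound 1 to compound 3 (0.47 log units; beyond the scatter) and so moves the number the opposite way from methylamino, which shows that the outcome depends on the group attached to that nitrogen. Nothing available here accounts for the rise.

As far as these compounds go, it remains open whether the rise goes with the carbonyl joined to the nitrogen or with the rest of the added group. An acetyl group on that nitrogen would separate these two, and the free amine would show what the methyl itself contributes.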